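The source may hold more compounds than are shown below. What is called first, only, known or untested is meant among the compounds shown, and "the series" means these compounds.

Working notes on the series. Compound 1 `c1ccc2c(c1)CN[C@@H](CN(CCCCNC1CCOCC1)[C@H]1CCCc3cccnc31)C2` gives 29.4 nM in a functional assay on cells for antagonist activity at C-X-C chemokine receptor type 4 (Homo sapiens), read by fluorescence and calcium flux, with stated times of 25 min and 90 s; on this read-out higher numbers stand for weaker inhibition and lower numbers for stronger inhibition. Compound 2 `C(=C/CN(C[C@H]1Cc2ccccc2CN1)[C@H]1CCCc2cccnc21)\CNCC1CCOCC1` gives 24.2 nM and compound 3 `C(=C/CN(C[C@H]1Cc2ccccc2CN1)[C@H]1CCCc2cccnc21)\CNC1CCOCC1` gives 15.5 nM in this assay; compound 1 thus stands within the scatter of both, nearest with a 1.2-fold lower number from compound 1 to compound 2 (0.08 log units; within the scatter) and furthest with a 1.9-fold lower number from compound 1 to compound 3 (0.28 log units; within the scatter), while the pair themselves show a 1.6-fold lower number from compound 2 to compound 3 (0.19 log units; within the scatter). Compound 4 `CC(C)(CCN(C[C@H]1Cc2ccccc2CN1)[C@H]1CCCc2cccnc21)CNC1CCOCC1` is not yet measured. It differs from compound 1 by a group of 11 heavy atoms (9 carbon, 1 nitrogen, 1 oxygen; one six-membered non-aromatic ring with 1 hetero atom) in place of a group of 9 heavy atoms (7 carbon, 1 nitrogen, 1 oxygen; one six-membered non-aromatic ring with 1 hetero atom), on a saturated chain carbon, two bonds along the chain from an amine nitrogen. The two measured steps away from compound 1 also reworked this chain and both stayed within the scatter, so no step beyond the scatter is expected here, in either direction. Compound 4 is therefore estimated at 25 nM in this assay, range 8 nM to 80 nM, which corresponds to an expected 1.2-fold lower number from compound 1 to compound 4 (0.07 log units; within the scatter).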

Compound 4, half-maximal inhibitory concentration: 36.3 nM
The estimate for compound 4 lay 1.5-fold (0.16 log units) below the measured number, and the stated range covers the measured number.
By their numbers in this assay, from the lowest: compounds 3, 2, 1 and 4 (each within the scatter of the next, the first and the last beyond it).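

The step of a 1.2-fold higher number from compound 1 to compound 4 (0.09 log units; within the scatter) in this assay shows that this saturated chain carbon, two bonds along the chain from an amine nitrogen, accepts the group of 11 heavy atoms in place of 2-((oxan-4-yl)amino)ethyl without a step beyond the scatter. The earlier steps shown here covered an unsaturated chain and a change on the amine nitrogen, whereas this one adds branching to the saturated chain. No measurement on hand bears on the reason for this result. Going by these compounds, whether a longer chain or a carboxylic acid at this place would also stay within the scatter remains open.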